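A Bridged Amine Replaces the Urea on the Shared Core

This account rests on a few compounds, and the source may have more. Where it says the series, first, only, none or still open, it means among the compounds named here.

In an assay on isolated protein for displacement of a labelled ligand from melanin-concentrating hormone receptor 1 (Homo sapiens) (a higher number here means a weaker inhibitor, a lower number a stronger inhibitor), compound 1 `Nc1ccc2cc(NC(=O)CCc3ccc(C(F)(F)F)cc3)ccc2n1` gives 240 nM, while compound 2 `CNC(=O)NC1CCN(c2ccc3cc(NC(=O)CCc4ccc(C(F)(F)F)cc4)ccc3n2)C1` gives 6 nM, the lowest of the two numbers. Within the data shown here, the only measured step, a 40-fold lower number from compound 1 to compound 2 (1.60 log units; beyond the scatter), shows how much the 3-((methylcarbamoyl)amino)pyrrolidin-1-yl group adds over a plain amino. Compound 3 `O=C(CCc1ccc(C(F)(F)F)cc1)Nc1ccc2nc(N3CC4CCC3C4)ccc2c1` carries a group of 7 heavy atoms (6 carbon, 1 nitrogen; one five-membered non-aromatic ring of carbon only, one five-membered non-aromatic ring with 1 hetero atom) in place of a group of 10 heavy atoms (6 carbon, 3 nitrogen, 1 oxygen; one five-membered non-aromatic ring with 1 hetero atom), on an aromatic carbon, on the carbon next to the ring nitrogen of the shared core. Because that step a 40-fold lower number from compound 1 to compound 2 (1.60 log units; beyond the scatter) was large and compound 3 keeps a ring amine but no urea, a moderate loss is expected, a 5.0-fold higher number from compound 2 to compound 3 (0.70 log units; beyond the scatter). Compound 3 is estimated at 30 nM, between 8 nM and 120 nM.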

Compound 3, half-maximal inhibitory concentration: 1 nM
Compound 3: the middle estimate sits 30-fold (1.48 log units) above what was measured; the whole stated range lies above it.
By their numbers in this assay, from the lowest: compound 3; then compound 2; then compound 1.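

In this assay the urea turns out not to be needed at this position: the change gives a 6.0-fold lower number from compound 2 to compound 3 (0.78 log units; beyond the scatter) even though the entering group has no hydrogen-bond donors and fewer heavy atoms. Measured against the plain amino, the same group gives a 240-fold lower number from compound 1 to compound 3 (2.38 log units; beyond the scatter) and so goes further than the urea-bearing ring did. Nothing measured here explains this gain.

From the compounds shown here alone, what the bridge itself contributes stays open: an unsubstituted pyrrolidine or a piperidine on this carbon would separate it from the effect of simply having a ring amine.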